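Swapping the naphthyl ether for a methylphenyl ether

The source may report more compounds than this note shows. Statements on the series, on what has been measured and on what is new or still open speak of the compounds shown alone.

Compound 2 `CCCc1nc2ccccc2c(=O)n1/N=C/c1ccc(Oc2ccc3ccccc3c2)cc1` sits in the middle of the three measured compounds in a physicochemical assay for lipophilicity, in phosphate buffer, measured as octanol-water partition; on this read-out higher numbers stand for higher lipophilicity and lower numbers for lower lipophilicity. Compound 1 `Cc1nc2ccccc2c(=O)n1/N=C/c1ccc(Oc2ccc3ccccc3c2)cc1` gives 5.22, compound 2 gives 6.12, and compound 3 `O=c1c2ccccc2nc(-c2ccccc2)n1/N=C/c1ccc(Oc2ccc3ccccc3c2)cc1` gives 6.53. The step of a number 0.90 log units higher from compound 1 to compound 2 (beyond the scatter) comes with an ethyl in place of hydrogen on the saturated chain carbon, and the step of a number 0.41 log units higher from compound 2 to compound 3 (beyond the scatter) with a phenyl in place of propyl on the core. Compound 4 `CCCc1nc2ccccc2c(=O)n1/N=C/c1ccc(Oc2ccc(C)cc2)cc1` keeps the propyl group of compound 2 and changes the other end of the molecule instead: 4-methylphenyl in place of naphthalen-2-yl on an oxygen on an aromatic ring. Within the data shown here, none of the measured steps touches that part of the molecule, so no direct reference exists for this change. The group that leaves carries two fused aromatic rings, the group that enters carries only one, so a drop in this assay is expected rather than a rise. The step from compound 2 to compound 4 in this assay is expected to be a number 0.62 log units lower from compound 2 to compound 4 (beyond the scatter). Compound 4 is therefore estimated at 5.5, within a range from 5 to 6.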

Compound 4, partition coefficient: 5.45
Estimate against measurement, compound 4: 0.05 log units above; low and high end bracket the measured number.
By their numbers in this assay, from the lowest: compounds 1 and 4 (each within the scatter of the next); then compound 2; then compound 3.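

Among these compounds, on the other side of the ether oxygen, a part untouched by the earlier steps, this assay also responds: 4-methylphenyl in place of naphthalen-2-yl on an oxygen on an aromatic ring gives a number 0.67 log units lower from compound 2 to compound 4 (beyond the scatter), so the read-out depends on more than the group on the core. Both groups consist of carbon only, carry no net charge and have no hydrogen-bond donors or acceptors, and they differ in having one six-membered aromatic ring or 2. Nothing among the data explains the size of this step.

As far as these compounds go, it remains open whether the same swap would give a similar step with the methyl of compound 1 or the phenyl of compound 3 on the core. Also open, from the compounds shown here alone, is how the number would respond to a phenyl carrying a carboxylic acid or an amine on that oxygen.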